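Meta-fluoro in place of para-methyl on a triazole aryl

A few compounds are considered here, and "the series" means these few. Any claim that something is new, unique, unknown or untested is made for them only; others in the source may bear on it.

Compound 1 `COc1ccccc1-c1ncnn1-c1cc(OC)c(OC)c(OC)c1` gives only a limit, > 10000 nM, in a functional assay on HL-60 cells (Homo sapiens) for antiproliferative activity, read by MTT assay, with a stated time of 72 h; on this read-out higher numbers stand for weaker inhibition and lower numbers for stronger inhibition.
Compound 2 `COc1cc(-n2ncnc2-c2ccc(F)cc2)cc(OC)c1OC` likewise gives only a limit, > 10000 nM, in this assay.
Compound 3 `COc1cc(-n2ncnc2-c2ccc(C)cc2)cc(OC)c1OC` gives 90 nM in this assay.

Compound 3 holds the only real number shown; the other two values are limits (the limit of > 10000 nM in this assay, at which 2 of the 3 values shown sit). The step of an at least 110-fold lower number from compound 2 to compound 3 (2.04 log units; beyond the scatter) was large, and so was an at least 110-fold lower number from compound 1 to compound 3 (2.04 log units; beyond the scatter); the step that the two limits leave unreadable from compound 1 to compound 2 cannot be read. Compound 4 `COc1cc(-n2ncnc2-c2cccc(F)c2)cc(OC)c1OC` differs from compound 3 by 3-fluorophenyl in place of 4-methylphenyl on an aromatic carbon. Since a para-fluoro reached only the limit, a meta-fluoro is expected to cost most of the activity of compound 3, so compound 4 is estimated at 3000 nM (range 300 nM to 30000 nM), an expected step of a 33-fold higher number from compound 3 to compound 4 (1.52 log units; beyond the scatter).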

Compound 4, half-maximal inhibitory concentration: > 10000 nM
Compound 4: no number, only a limit; the forecaster's own chance of this, stated with the estimate: 45%; middle value at least 3.3-fold (0.52 log units) away from the limit.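

With an at least 110-fold higher number from compound 3 to compound 4 (2.04 log units; beyond the scatter), the 3-fluorophenyl group joins the 4-fluorophenyl and 2-methoxyphenyl groups, leaving 4-methylphenyl as the only group on this aromatic carbon that gives a number: the limit of > 10000 nM in this assay, at which 3 of the 4 values shown sit. The value of compound 4 is a limit, as are those of compound 1 and compound 2, so the steps among these three cannot be read and the two fluorophenyl groups cannot be ranked.

This change alters both the substituent and its ring position, and the compounds shown do not separate the two. As far as these compounds go, whether 3-methylphenyl, 4-ethylphenyl or 4-aminophenyl would give a number in this assay remains open.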